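From cyclobutyl to cyclopropylmethyl on a shared core

The source may report more compounds than this note shows. Statements on the series, on what has been measured and on what is new or still open speak of the compounds shown alone.

Measured in a functional assay (aorta) with Rattus norvegicus as the target; on this read-out higher numbers stand for an effect only at larger amounts of compound and lower numbers for an effect already at smaller amounts:
Compound 1 `CNC1=NS(=O)(=O)c2cc(F)ccc2N1`: > 300 uM (a limit of the assay, not a number)
Compound 2 `O=S1(=O)NC(NC2CCC2)=Nc2ccc(F)cc21`: 71.8 uM

Among the measured compounds shown here, compound 2 gives 71.8 uM, the only true number so far. For the measured compounds named here, the single other result is the limit reached by compound 1, so there is no measured step to learn from and no range of numbers against which to place compound 2.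

Compound 3 `O=S1(=O)NC(NCC2CC2)=Nc2ccc(F)cc21` has the same atoms as compound 2, joined differently: cyclopropylmethyl in place of cyclobutyl on an amine nitrogen. In words, cyclopropylmethyl sits in place of cyclobutyl on an amine nitrogen. With only compound 2 at 71.8 uM as a guide, no step beyond the scatter is expected in this assay, in either direction. The expected step is a 1.1-fold higher number from compound 2 to compound 3 (0.05 log units; within the scatter), which should stay within the usual scatter. For compound 3 the estimate is 80 uM, with an expected range from 30 uM to 220 uM.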

Compound 3, concentration for half-maximal effect: 146 uM
Compound 3: the middle estimate sits 1.8-fold (0.26 log units) below what was measured; the range from low to high includes it.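

In this assay, rearranging the same atoms within the group on this amine nitrogen is enough to change the result (a 2.0-fold higher number from compound 2 to compound 3 (0.31 log units; beyond the scatter)). Among the compounds shown here, this is the first measured step on the shared core, and it shows that this position responds to the arrangement of the group's carbons, not just to which atoms are present. The step is modest, but on this read-out the cyclobutyl of compound 2 gives an effect at smaller amounts of compound than the cyclopropylmethyl of compound 3.

From the compounds shown here alone, it remains open how a larger ring such as cyclopentyl, a longer chain such as pentyl, or a chain ending in an alcohol would read at this nitrogen. Compound 1 gives only a limit, so it offers no number for comparison: the limit of > 300 uM in this assay, at which 1 of the 3 values shown sits.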